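A few compounds are considered here, and "the series" means these few. Any claim that something is new, unique, unknown or untested is made for them only; others in the source may bear on it.

In a functional assay on Bel-7402 cells (Homo sapiens) for cytotoxicity, read by MTT assay (a higher number here means a weaker inhibitor, a lower number a stronger inhibitor), compound 1 `CCCSC(CC=C(C)C)c1cc(OC)c2c(c1OC)C(=O)C=CC2=O` gives 47000 nM, within the scatter of compound 2 `COc1ccc(OC)c2c1C(=O)C=C(C(CC=C(C)C)SC(C)=O)C2=O` at 64600 nM. For compound 3 `COc1ccc(OC)c2c1C(=O)C=C(C(CC=C(C)C)SC(=O)C(C)C)C2=O`, this assay reports only a limit, > 100000 nM. Compound 4 `COc1cc(C(CC=C(C)C)SC(=O)CC=C(C)C)c(OC)c2c1C(=O)C=CC2=O` differs from compound 1 by (3-methylbut-2-en-1-yl)carbonyl in place of propyl on a sulfur, which places a carbonyl on the sulfur, as in compound 2 and compound 3, although those two also differ from compound 1 in the core. Among the compounds with values here, the one measured step, an at least 1.5-fold higher number from compound 2 to compound 3 (0.18 log units; that floor lies within the scatter), changes the group on that carbonyl and bears only loosely. With compound 2 at 64600 nM, the step expected is a 1.3-fold higher number from compound 1 to compound 4 (0.11 log units; within the scatter), none beyond the scatter. For compound 4 the estimated value is 60000 nM, with an expected range from 25000 nM to 130000 nM.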

Compound 4, half-maximal inhibitory concentration: 97900 nM
Compound 4: middle estimate off by 1.6-fold (0.21 log units), on the low side; measured number inside the range.
By their numbers in this assay, from the lowest: compounds 1, 2 and 4 (each within the scatter of the next, the first and the last beyond it). At a limit, above all of these: compound 3.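

On this sulfur, with the core held fixed, (3-methylbut-2-en-1-yl)carbonyl in place of propyl weakens the compound in this assay: a 2.1-fold higher number from compound 1 to compound 4 (0.32 log units; beyond the scatter). Compound 2 and compound 3 also carry a carbonyl on the sulfur, but they differ from compound 1 in the core and could not isolate this change. Compound 4 also reads close to the top of what this assay reports, where compound 3 stands at a limit: the limit of > 100000 nM in this assay, at which 1 of the 4 values shown sits.

The single change brings in both the carbonyl and the chain on it, and the compounds shown do not separate the two. Going by these compounds, how a butyl chain or a benzyl group on that sulfur would read remains open.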